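The source may report more compounds than this note shows. Statements on the series, on what has been measured and on what is new or still open speak of the compounds shown alone.

Compound 1 `O=C1CCc2cccc(Nc3ncc(-c4ccc(C(F)(F)F)cc4)o3)c2C1`: 374 nM
Compound 2 `CC(C)c1nc(Nc2cccc3c2CC(O)CC3)oc1-c1ccc(C(F)(F)F)cc1`: 114 nM

In an in vitro functional assay on cells for antagonist activity at transient receptor potential cation channel subfamily V member 1 (Homo sapiens), read by FLIPR and calcium flux (a lower number here means a stronger inhibitor, a higher number a weaker inhibitor), compound 2 gives 114 nM, the lowest of the two numbers; compound 1 gives 374 nM, and the gap between them lies beyond the scatter. Compound 3 `OC1CCc2cccc(Nc3nc(-c4ccc(F)cc4)c(-c4ccc(C(F)(F)F)cc4)o3)c2C1` is not yet measured. It differs from compound 2 by 4-fluorophenyl in place of isopropyl on an aromatic carbon. Going by the values given here, no step between measured compounds tests this change, so the expectation rests on compound 2 alone. Compound 3 is therefore expected to change little, the step being estimated as a 1.3-fold higher number from compound 2 to compound 3 (0.12 log units; within the scatter), possibly within the scatter. Compound 3 is estimated at 150 nM, with a range from 40 nM to 600 nM.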

Compound 3, half-maximal inhibitory concentration: 1.3 nM
For compound 3 the middle estimate is 120-fold (2.06 log units) above the measured one; the whole stated range lies above it.
By their numbers in this assay, from the lowest: compound 3; then compound 2; then compound 1.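

In this assay, the aromatic carbon next to the ring nitrogen proves highly sensitive to its substituent: 4-fluorophenyl in place of isopropyl gives an 88-fold lower number from compound 2 to compound 3 (1.94 log units; beyond the scatter). This carbon therefore accepts a six-membered aromatic ring, with a large gain in inhibition. Nothing in the available data accounts for the size of this step. From the compounds shown here alone, it remains open whether phenyl, 4-chlorophenyl or cyclohexyl on this carbon would give a similar number, which would separate the contribution of the ring from that of the fluorine. Going by these compounds, whether the step carries over to the carbonyl-bearing core of compound 1 also remains open.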